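The source may report more compounds than this note shows. Statements on the series, on what has been measured and on what is new or still open speak of the compounds shown alone.

Two compounds have been measured in a functional assay on MDA-MB-435 cells (Homo sapiens) for cytotoxicity, read by sulforhodamine B assay, with a stated time of 48 h; a higher number here means a weaker inhibitor of growth, a lower number a stronger inhibitor of growth:

- compound 1, `ClCc1ccccc1Cn1cnc2ncnc(Cl)c21`: compound 1 gives 1940 nM
- compound 2, `ClCc1cccc(Cn2cnc3nc(Cl)nc(Cl)c32)c1`: compound 2 gives 1470 nM

Compound 1 has the highest of these two numbers in this assay, but its nearest neighbour, compound 2, sits only slightly lower, and that gap lies within the usual scatter of this kind of measurement. So the two values show no real difference between compound 1 and compound 2.

The next compound, compound 3, `ClCc1ccccc1Cn1cnc2nc(Cl)nc(Cl)c21`, differs from compound 1 in one place: chloro in place of hydrogen on an aromatic carbon. Among the compounds with values here, no step between measured compounds shows what this single change does on its own. Compound 2 already carries two chloro groups on the same core and its value gives no sign of a large effect, so for compound 3 the expected outcome is a step of a 1.2-fold lower number from compound 1 to compound 3 (0.08 log units; within the scatter) from compound 1, that is, no change beyond the scatter in this assay. On that basis compound 3 is expected to give about 1600 nM, with a likely range from 600 nM to 4500 nM.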

Compound 3, concentration for 50% growth inhibition: 16600 nM
Beside the measured number, compound 3's estimate is 10-fold (1.02 log units) below it, and the stated range ends below it.
By their numbers in this assay, from the lowest: compounds 2 and 1 (each within the scatter of the next); then compound 3.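

In this assay, chloro in place of hydrogen on the aromatic carbon between two ring nitrogen atoms gives an 8.6-fold higher number from compound 1 to compound 3 (0.93 log units; beyond the scatter), a step beyond the scatter and towards weaker inhibition of growth. Within the data shown here, the two earlier compounds offered no step that could isolate a single change, so this is the first sign that this position is not indifferent: one added chlorine atom, with no ring and no charge, is enough to move the number clearly. No measurement shown here explains how this change produces the step.

On these data alone, it remains open whether the weaker inhibition is specific to chloro or would also appear with another group at this carbon, such as fluoro, a methoxy group or an amine. As far as these compounds go, it is also open whether the step would keep its size with the chloromethyl group placed as it is in compound 2, which carries chloro at this same carbon and gives 1470 nM.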